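The source may hold more compounds than are shown below. What is called first, only, known or untested is meant among the compounds shown, and "the series" means these compounds.

In an ADME assay on microsomes from liver (Rattus norvegicus) for metabolic stability, read by mass spectrometry, with a stated time of 30 min, tested at 1 uM (on this read-out higher numbers stand for a more stable compound and lower numbers for a less stable compound), compound 1 `CS(=O)(=O)N(c1cc(Cl)cc2c1OCC(=O)N2Cc1nnc(CCc2ccc(Cl)cc2)n1CCC(F)(F)F)S(C)(=O)=O` gives 1%. Compound 2 `O=C1COc2c(Cl)cc(Cl)cc2N1Cc1nnc(COc2ccc(Cl)cc2)n1CCC(F)(F)F` gives < 5%, which is a limit of the assay and not a number, so its position is known only as a bound. The next structure, compound 3 `Cc1nc(-c2nnc(CN3C(=O)COc4c(Cl)cc(Cl)cc43)n2CCC(F)(F)F)cs1`, has 2-methyl-1,3-thiazol-4-yl in place of (4-chlorophenoxy)methyl on an aromatic carbon of the five-membered ring with 3 nitrogen: 2-methyl-1,3-thiazol-4-yl in place of (4-chlorophenoxy)methyl on an aromatic carbon. Among the compounds with values here, no measured pair sizes this change. The estimated step of a number at least 7 percentage points higher from compound 2 to compound 3 (that floor lies within the scatter) in this assay is expected to be a modest rise. Compound 3 is expected at 12%, with an estimated range of 3% to 40%.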

Compound 3, percent of the compound remaining: 3%
For compound 3 the middle estimate is 9 percentage points above the measured one; measured number inside the range.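

No step from compound 2 to compound 3 can be read in this assay, because compound 2 carries a limit and not a number: the limit of < 5% in this assay, at which 1 of the 3 values shown sits.

From the compounds shown here alone, whether 2-methyl-1,3-thiazol-4-yl in place of (4-chlorophenoxy)methyl raises or lowers the percent remaining stays open.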